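Chloro Substitution on Two Related Cores Tested for Cytotoxicity

The compounds below may be only part of what the source reports. "The series", "measured", "known", "first", "only" and "open" are said of these compounds alone.

Compound 1, `O=c1[nH]nc2n(c1=O)CCN2c1ccccc1`, and compound 2, `N/N=C1\NCCN1c1ccccc1`, share a phenyl ring attached to a nitrogen, but the rest of the two cores differs; the difference between the two cores is not broken down here. In a functional assay on T47D cells (Homo sapiens) for cytotoxicity, with a stated time of 72 h, tested at 50 ug/mL (a higher number here means a stronger effect of the compound at the concentration tested, a lower number a weaker effect), compound 1 gives 0%, and in this assay compound 2 gives 0%, so the two stand level at the digits shown.

Compound 3, `O=c1[nH]nc2n(c1=O)CCN2c1ccc(Cl)cc1`, is compound 1 with chloro in place of hydrogen on an aromatic carbon. In this assay compound 3 gives 1%, and the step of a number 1 percentage points higher from compound 1 to compound 3 (within the scatter) lies within the usual scatter of such measurements, so no real shift can be read from it.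

Compound 4, `N/N=C1\NCCN1c1cccc(Cl)c1`, has not yet been measured. It is compound 2 with chloro in place of hydrogen on an aromatic carbon. This is the same kind of change as from compound 1 to compound 3, though not the same one: in compound 3 the chloro sits para to a large group, whereas in compound 4 it sits meta to a group of 7 heavy atoms. Since the chloro made no visible difference from compound 1 to compound 3, and compound 2 itself sits at 0%, the step from compound 2 to compound 4 in this assay is expected to be a number 2 percentage points higher from compound 2 to compound 4 (within the scatter), small as before. Compound 4 is therefore estimated at 2%, most likely between 0% and 12%.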

Compound 4, a percentage reported as inhibition, at one concentration (the size of the read-out at that concentration, not a potency): 0%
Beside the measured number, compound 4's estimate is 2 percentage points above it; the measured number falls inside the stated range.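

In this assay, chloro in place of hydrogen on an aromatic carbon gives no change at the digits printed from compound 2 to compound 4 (within the scatter). Set beside the same kind of change on the core of compound 1, the two steps do not differ: the same change on two cores in this assay, a number 1 percentage points higher (within the scatter) from compound 1 to compound 3 and no change at the digits printed (within the scatter) from compound 2 to compound 4, 1 percentage points apart, within the scatter of two such steps. Within these four compounds, then, the change carries from one core to the other as no visible effect, but this shows only that neither pair rises from close to zero on this read-out; it cannot tell whether chloro would act alike on the two cores in compounds with a clear effect, and in compound 4 the chloro sits meta to a group of 7 heavy atoms, which is not the place it holds in compound 3.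

The compounds shown leave open whether anything on the phenyl ring can lift either core to a clear level of cytotoxicity, as only hydrogen and chloro appear there and a group such as an amine, a carboxylic acid or a longer chain is not among them. Also open, going by these compounds, is whether chloro in one and the same place on both cores would give matching results, and whether either core would show an effect at a higher concentration.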